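The compounds below may be only part of what the source reports. "The series", "measured", "known", "first", "only" and "open" are said of these compounds alone.

Measured in a functional assay on HCT-116 cells (Homo sapiens) for cytotoxicity, read by MTT assay, with a stated time of 72 h; on this read-out higher numbers stand for weaker inhibition and lower numbers for stronger inhibition:
- compound 1 `O=C1c2c[n+]([O-])c3ccccc3c2C(=O)c2c1c1ccccc1n2Cc1cn(CC(O)CO)nn1`: 250 nM
- compound 2 `CN1CCN(CCCCn2c3c(c4ccccc42)C(=O)c2c[n+]([O-])c4ccccc4c2C3=O)CC1`: 10 nM
- compound 3 `O=C1c2c[n+]([O-])c3ccccc3c2C(=O)c2c1c1ccccc1n2CCN1CCCC1`: 270 nM

Compound 3 stands at 270 nM, level with compound 1 and far from compound 2. The next structure is compound 4 `O=C1c2c[n+]([O-])c3ccccc3c2C(=O)c2c1c1ccccc1n2CCCCN1CCCCC1`, and the change is 2-(piperidin-1-yl)ethyl in place of pyrrolidin-1-yl on a saturated chain carbon, two bonds along the chain from an aromatic nitrogen. Read one bond further out, this is 2-(pyrrolidin-1-yl)ethyl to 4-(piperidin-1-yl)butyl.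

The most relevant measurement is a 27-fold higher number from compound 2 to compound 3 (1.43 log units; beyond the scatter). It concerns the same place, with 2-(4-methylpiperazin-1-yl)ethyl where compound 4 has 2-(piperidin-1-yl)ethyl. The other step, a 1.1-fold higher number from compound 1 to compound 3 (0.03 log units; within the scatter), involves a different group. Going by the values given here, no measured compound carries piperidin-1-yl, so a step beyond the scatter but smaller than the large one is expected in this assay, toward a lower number. The expected step is a 6.8-fold lower number from compound 3 to compound 4 (0.83 log units; beyond the scatter). For compound 4 the estimate is 40 nM, with an expected range of 10 nM to 150 nM.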

Compound 4, half-maximal inhibitory concentration: 200 nM
Estimate against measurement, compound 4: 5.0-fold (0.70 log units) below, outside the stated range (above it).
By their numbers in this assay, from the lowest: compound 2; then compounds 4, 1 and 3 (each within the scatter of the next).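

In this assay, changing 2-(pyrrolidin-1-yl)ethyl to 4-(piperidin-1-yl)butyl gives a 1.4-fold lower number from compound 3 to compound 4 (0.13 log units; within the scatter), and the triazole-bearing compound is no further away, with a 1.3-fold lower number from compound 1 to compound 4 (0.10 log units; within the scatter); a longer chain ending in piperidin-1-yl therefore does not reach the level of compound 2. On the same chain, piperidin-1-yl in place of 4-methylpiperazin-1-yl gives a 20-fold higher number from compound 2 to compound 4 (1.30 log units; beyond the scatter), so the large gap here follows the terminal ring, not chain length alone. No measurement available here explains this gap.

Ring and chain change together from compound 3 to compound 4, so their separate contributions remain unresolved. Also open, going by these compounds, is how a 4-(morpholin-4-yl)butyl group or a 2-(4-methylpiperazin-1-yl)ethyl group would read at this position.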